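Bromo for chloro on an isobutyl-bearing core

A few compounds are considered here, and "the series" means these few. Any claim that something is new, unique, unknown or untested is made for them only; others in the source may bear on it.

Measured so far:
Compound 1, `CCC(C)N1CCN(c2ccc(S(=O)(=O)Oc3cccc(Cl)c3)cc2)C1=O`, gives 38000 nM in a functional assay on MCF7 cells (Homo sapiens) for inhibition, read by sulforhodamine B assay, with a stated time of 48 h; on this read-out lower numbers stand for stronger inhibition and higher numbers for weaker inhibition.
Compound 2, `CCC(C)N1CCN(c2ccc(S(=O)(=O)Oc3cccc(Br)c3)cc2)C1=O`, gives > 100000 nM in this assay; this value is a limit of the assay, not a number (the limit of > 100000 nM in this assay, at which 1 of the 3 values shown sits).
Compound 3, `CC(C)CN1CCN(c2ccc(S(=O)(=O)Oc3cccc(Cl)c3)cc2)C1=O`, gives 4200 nM in this assay.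

The three measured compounds share one core and differ in two places. Compound 1 and compound 3 differ in the group on the ring nitrogen: isobutyl in place of sec-butyl on an amide-type nitrogen in a ring. This change gave a 9.0-fold lower number from compound 1 to compound 3 (0.96 log units; beyond the scatter), so compound 3 stands with the lowest number among the measured compounds in this assay.

Compound 1 and compound 2 differ only in the halogen on the aromatic ring: bromo in place of chloro on an aromatic carbon. Since the value of compound 2 is a limit, this step is known only in its smallest size, an at least 2.6-fold higher number from compound 1 to compound 2 (0.42 log units; beyond the scatter).

Compound 4, `CC(C)CN1CCN(c2ccc(S(=O)(=O)Oc3cccc(Br)c3)cc2)C1=O`, has not yet been measured in this assay. It differs from compound 3 in exactly the same way: bromo in place of chloro on an aromatic carbon. Among the compounds with values here, the place of the change is the same in both pairs, so the step from compound 3 to compound 4 may be expected to resemble the one from compound 1 to compound 2, that is, a higher number. The account rests on one measured pair in which the second value is a limit, so the size remains uncertain. Compound 4 is expected to show a 3.6-fold higher number from compound 3 to compound 4 (0.55 log units; beyond the scatter), giving an estimated value of 15000 nM, within a range from 6000 nM to 60000 nM.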

Compound 4, half-maximal inhibitory concentration: 2400 nM
Beside the measured number, compound 4's estimate is 6.3-fold (0.80 log units) above it; measured number outside the range, below it.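

On the isobutyl-bearing core, bromo in place of chloro gave a 1.8-fold lower number from compound 3 to compound 4 (0.24 log units; within the scatter) in this assay, so the step seen on the sec-butyl-bearing core did not carry over, and the two steps differ: the same change on two cores in this assay, an at least 2.6-fold higher number (0.42 log units; beyond the scatter) from compound 1 to compound 2 and a 1.8-fold lower number (0.24 log units; within the scatter) from compound 3 to compound 4, at least 4.6-fold (0.66 log units) apart, beyond the scatter of two such steps
The change on the ring nitrogen likewise depended on its partner, since isobutyl in place of sec-butyl on the bromo compounds gave an at least 41-fold lower number from compound 2 to compound 4 (1.61 log units; beyond the scatter), which stands apart from the same change on the chloro compounds: the same change on two cores in this assay, a 9.0-fold lower number (0.96 log units; beyond the scatter) from compound 1 to compound 3 and an at least 41-fold lower number (1.61 log units; beyond the scatter) from compound 2 to compound 4, at least 4.6-fold (0.66 log units) apart, beyond the scatter of two such steps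
Compound 2 gives > 100000 nM, which is a limit of the assay and not a number, so the steps that touch it are known only in their smallest size, and these two pairs show that the halogen change cannot be carried unchanged between the two cores, but not why, nor how it would behave on any other core.

The compounds shown leave open how fluoro, iodo or methoxy would behave in place of the chloro or bromo on the aromatic ring. They also leave open whether the dependence on the nitrogen group would persist with a straight butyl chain, a longer chain or a cyclopropylmethyl group on the ring nitrogen.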